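Anilide amides of a nitrobenzofurazan chain: a dimethoxyphenyl variant

A few compounds are considered here, and "the series" means these few. Any claim that something is new, unique, unknown or untested is made for them only; others in the source may bear on it.

Compound 1 `O=C(CCC(=O)OCCCCCCSc1ccc([N+](=O)[O-])c2nonc12)Nc1ccccc1` – 2120 nM
Compound 2 `COc1ccccc1NC(=O)CCC(=O)OCCCCCCSc1ccc([N+](=O)[O-])c2nonc12` – 2850 nM
Compound 3 `Cc1ccc(NC(=O)CCC(=O)OCCCCCCSc2ccc([N+](=O)[O-])c3nonc23)cc1` – 3340 nM

Three compounds of this series share one core and differ only in the aryl group on the amide nitrogen. In a functional assay on HOS cells (Homo sapiens) for inhibition, read by MTT assay, with a stated time of 72 h (a higher number here means a weaker inhibitor, a lower number a stronger inhibitor), compound 1 gives 2120 nM, compound 2 gives 2850 nM and compound 3 gives 3340 nM. Compound 2 stands second highest of the three numbers, but its neighbours lie close: a 1.2-fold higher number from compound 2 to compound 3 (0.07 log units; within the scatter) and, in the other direction, a 1.3-fold higher number from compound 1 to compound 2 (0.13 log units; within the scatter). The third step, a 1.6-fold higher number from compound 1 to compound 3 (0.20 log units; within the scatter), is equally small. Nothing in these three numbers separates one aryl group from another.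

Compound 4 `COc1ccc(NC(=O)CCC(=O)OCCCCCCSc2ccc([N+](=O)[O-])c3nonc23)cc1OC` has not yet been measured. Its difference from compound 2 is 3,4-dimethoxyphenyl in place of 2-methoxyphenyl on an amide-type nitrogen. Going by the values given here, the steps that bear on this change are the exchange of hydrogen for methoxy on the aromatic ring from compound 1 to compound 2 and the swap of one substituted phenyl for another from compound 2 to compound 3; both stayed within the scatter. A second methoxy group on the ring is therefore expected to leave this assay essentially unchanged, with no step beyond the scatter in either direction: a 1.1-fold higher number from compound 2 to compound 4 (0.02 log units; within the scatter). Compound 4 is estimated at 3000 nM, with a range from 1500 nM to 6000 nM.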

Compound 4, half-maximal inhibitory concentration: 1390 nM
The estimate for compound 4 lay 2.2-fold (0.33 log units) above the measured number, outside the stated range (below it).
By their numbers in this assay, from the lowest: compounds 4, 1, 2 and 3 (each within the scatter of the next, the first and the last beyond it).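

Going by these compounds alone, with 3,4-dimethoxyphenyl on the amide nitrogen, the aryl group separates compounds for the first time in this assay: replacing 2-methoxyphenyl gives a 2.1-fold lower number from compound 2 to compound 4 (0.31 log units; beyond the scatter), and replacing 4-methylphenyl gives a 2.4-fold lower number from compound 3 to compound 4 (0.38 log units; beyond the scatter), both modest steps. The separation does not extend to the unsubstituted aryl group, since replacing phenyl gives a 1.5-fold lower number from compound 1 to compound 4 (0.18 log units; within the scatter), so compound 4 cannot be called the strongest of the four. This position therefore responds to the exchange of one substituted phenyl for another, but substitution as such has no single direction here, as compound 1 stays within the scatter of each of the other three.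

No accompanying evidence is available to account for these steps. Compound 4 differs from compound 2 in both the number and the placing of its methoxy groups, so the compounds shown leave open which of these differences carries the step, and also whether a chlorine, an amine or a carboxylic acid on the phenyl ring would move the number in the same direction.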